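A few compounds are considered here, and "the series" means these few. Any claim that something is new, unique, unknown or untested is made for them only; others in the source may bear on it.

The compounds here share one core and differ only in the group attached to the carbonyl carbon of an amide. Compound 1 is `O=C(Nc1ccc(Cl)cc1CN1C(=O)c2ccccc2C1=O)c1ccccc1[N+](=O)[O-]`. In an assay on CHO cells for positive allosteric modulation of metabotropic glutamate receptor 5 (Rattus norvegicus), read by FLIPR (on this read-out higher numbers stand for an effect only at larger amounts of compound and lower numbers for an effect already at smaller amounts), compound 1 gives < 1000 nM, which is a limit of the assay and not a number. Compound 2 is `O=C(Nc1ccc(Cl)cc1CN1C(=O)c2ccccc2C1=O)c1ccccc1C(F)(F)F`, with trifluoromethyl in place of nitro on an aromatic carbon. In this assay compound 2 gives < 1000 nM, again a limit. Compound 3 is `O=C(Nc1ccc(Cl)cc1CN1C(=O)c2ccccc2C1=O)C1CCCCC1`. In this assay compound 3 gives < 1000 nM, also a limit. Because the limit of < 1000 nM in this assay, at which 3 of the 3 values shown sit, none of the steps among these three can be read: a step that the two limits leave unreadable from compound 1 to compound 2, a step that the two limits leave unreadable from compound 1 to compound 3 and a step that the two limits leave unreadable from compound 2 to compound 3. Compound 1 therefore stands only at a limit, as do the two others, so no order among them can be given. Compound 4 is `O=C(Nc1ccc(Cl)cc1CN1C(=O)c2ccccc2C1=O)c1cccnn1`; it differs from compound 1 by pyridazin-3-yl in place of 2-nitrophenyl on a carbonyl carbon. All three measured steps change the group on the carbonyl carbon or a substituent on it, so each bears on this change, yet none shows a size. In this assay a step within the scatter, in no set direction, is therefore expected: a step that the limit leaves unreadable from compound 1 to compound 4. Compound 4 is expected to give 400 nM, within a range from 80 nM to 2000 nM.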

Compound 4, half-maximal effective concentration: < 1000 nM
Compound 4 ended at the assay's limit; the forecaster's own chance of this, stated with the estimate: 40%; the middle value does not contradict the limit.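

In this assay compound 4 gives < 1000 nM, a limit of the assay and not a number. Its steps from compound 1, compound 2 and compound 3 cannot be read, for one shared reason: the limit of < 1000 nM in this assay, at which 4 of the 4 values shown sit. The compounds shown leave open whether changing the group on the carbonyl carbon alters the result in this assay at all, and by how much.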